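A 3-cyanophenyl counterpart of compound 1

A few compounds are considered here, and "the series" means these few. Any claim that something is new, unique, unknown or untested is made for them only; others in the source may bear on it.

Going by the values given here, in a functional assay (strain AB) with Danio rerio as the target, read by microscopy, with a stated time of 1 h (on this read-out higher numbers stand for an effect only at larger amounts of compound and lower numbers for an effect already at smaller amounts), compound 1 (`CCN1CCc2c(sc(NC(=O)Nc3cccc(Cl)c3Cl)c2C(N)=O)C1`) gives 17400 nM as the highest of three numbers so far. Compound 2 (`CC[N+]1(CC2CC2)CCc2c(sc(NC(=O)Nc3ccc(Cl)cc3)c2C(N)=O)C1`) gives 100 nM and compound 3 (`NC(=O)c1c(NC(=O)Nc2ccc(Cl)cc2)sc2c1CCN(CCCNC(=O)CCc1cccc3ccccc13)C2`) gives 110 nM and both numbers lie lower than that of compound 1, beyond the scatter. Compound 4 (`CCN1CCc2c(sc(NC(=O)Nc3cccc(C#N)c3)c2C(N)=O)C1`) carries 3-cyanophenyl in place of 2,3-dichlorophenyl on an amide-type nitrogen. Among the compounds with values here, no measured pair isolates this change, and compound 2 and compound 3 differ from compound 1 in more than one place. In this assay no step beyond the scatter is therefore expected, and the estimate is a step (a 1.7-fold lower number from compound 1 to compound 4 (0.24 log units; within the scatter)) of modest size. For compound 4 the expected value is 10000 nM (estimated range 2500 nM to 40000 nM).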

Compound 4, half-maximal effective concentration: 10300 nM
The estimate for compound 4 lay 1.0-fold (0.01 log units) below the measured number, within the range that was stated.
By their numbers in this assay, from the lowest: compounds 2 and 3 (each within the scatter of the next); then compounds 4 and 1 (each within the scatter of the next).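

In this assay, going by these compounds alone, the first step at this position, on an amide-type nitrogen, is a 1.7-fold lower number from compound 1 to compound 4 (0.23 log units; within the scatter). Exchanging 2,3-dichlorophenyl for 3-cyanophenyl, which removes both chlorines and brings in a nitrile with one hydrogen-bond acceptor, therefore leaves the number unchanged within the scatter. Nothing available explains this outcome. From the compounds shown here alone, it remains open whether a different group at this place, such as a phenyl ring carrying a methoxy group or a carboxylic acid, would move the number beyond the scatter on the core of compound 1.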